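The source may report more compounds than this note shows. Statements on the series, on what has been measured and on what is new or still open speak of the compounds shown alone.

Series notes. The shared core of compound 1 `CCCn1c(=O)[nH]c2nc(-c3ccc(S(=O)(=O)N4CCN(c5ccc(F)cc5)CC4)cc3)[nH]c2c1=O` carries a sulfonyl-linked ring bearing a 4-fluorophenyl group; in an assay on CHO cells for displacement of a labelled ligand from adenosine receptor A3 (Homo sapiens), read by scintillation counting, with a stated time of 45 min, tested at 1 uM, in the presence of a further agent that is not named here (a higher number here means more inhibition at the concentration tested (going by the name of the read-out), a lower number less inhibition), compound 1 gives 38%. Compound 2 `CCCn1c(=O)[nH]c2nc(-c3ccc(S(=O)(=O)N4CCN(Cc5cccc(C)c5)CC4)cc3)[nH]c2c1=O` carries 3-methylbenzyl at the same position and gives 17% in this assay. Compound 3 `CCCn1c(=O)[nH]c2nc(-c3ccc(S(=O)(=O)N4CCN(c5ccccc5F)CC4)cc3)[nH]c2c1=O`, with 2-fluorophenyl there, gives 9% in this assay; this is the lowest of the three numbers, though its gap to compound 2 is within the usual scatter, and only compound 1 stands clearly apart, as the step of a number 29 percentage points lower from compound 1 to compound 3 (beyond the scatter) shows. The step of a number 8 percentage points lower from compound 2 to compound 3 (within the scatter) is within the scatter.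

Compound 4 `CCCn1c(=O)[nH]c2nc(-c3ccc(S(=O)(=O)N4CCN(Cc5ccc(Br)c(F)c5)CC4)cc3)[nH]c2c1=O` is not yet measured. Change from compound 3: 4-bromo-3-fluorobenzyl in place of 2-fluorophenyl on an amine nitrogen in a ring. The step that bears on it is a number 8 percentage points lower from compound 2 to compound 3 (within the scatter), where exchanging a benzyl-type group for 2-fluorophenyl left the number essentially unchanged; reversing that kind of exchange is therefore expected to give no step beyond the scatter, a number 6 percentage points higher from compound 3 to compound 4 (within the scatter). Compound 4 is estimated at 15% in this assay, between 4% and 30%.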

Compound 4, a percentage reported as inhibition, at one concentration (the size of the read-out at that concentration, not a potency): 27%
Compound 4: the middle estimate sits 12 percentage points below what was measured; the measured number falls inside the stated range.
By their numbers in this assay, from the lowest: compounds 3, 2 and 4 (each within the scatter of the next, the first and the last beyond it); then compound 1.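

On the amine nitrogen in the ring, the two benzyl-type groups are not separated in this assay (a number 10 percentage points higher from compound 2 to compound 4 (within the scatter)), so the two sets of substituents on the benzyl ring cannot be told apart here. Even so, 4-bromo-3-fluorobenzyl does stand clear of 2-fluorophenyl (a number 18 percentage points higher from compound 3 to compound 4 (beyond the scatter)), which the 3-methylbenzyl comparison did not show, and it also stands clear of 4-fluorophenyl, on the other side (a number 11 percentage points lower from compound 1 to compound 4 (beyond the scatter)), so this one benzyl-type group falls between the two fluorophenyl groups. Nothing beyond these numbers bears on why the exchange shifts the read-out.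

Still open, going by these compounds, is how an unsubstituted benzyl or phenyl group, or a simple ethyl chain, would read on the same nitrogen. As 4-bromo-3-fluorobenzyl carries both halogens at once, the share of the bromine and that of the fluorine also remain unresolved.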